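The source may hold more compounds than are shown below. What is called first, only, known or untested is meant among the compounds shown, and "the series" means these compounds.

In a functional assay on A549 cells (Homo sapiens) for antiproliferative activity, read by MTT assay, with a stated time of 72 h (a lower number here means a stronger inhibitor, a higher number a weaker inhibitor), compound 3 (`CCCCCCCCCNC[C@@H]1OC[C@H](N)[C@H]1O`) gives > 128000 nM, which is a limit of the assay and not a number. Its position therefore cannot be placed more exactly on the numbers available. Compound 1 (`CCCCCCCCNC[C@@H]1OC[C@H](N)[C@@H]1O`) gives > 128000 nM, also a limit. Compound 2 (`CCCCCCCNC[C@@H]1OC[C@H](N)[C@@H]1O`) gives > 128000 nM, likewise a limit. The whole data set consists of the limit of > 128000 nM in this assay, at which 3 of the 3 values shown sit, so no measured potency serves as an anchor.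

Compound 4 (`CCCCCCCCCNC[C@@H]1OC[C@H](N)[C@@H]1O`) is the stereoisomer of compound 3: the two compounds have the same atoms and bonds and differ only in configuration as drawn: 1 of 3 stereo elements differ; a stereocentre at a saturated ring carbon is drawn R in compound 3 and S in compound 4. Going by the values given here, in this respect it shares the configuration drawn for compounds 1 and 2, while a stereocentre at a saturated ring carbon is drawn S rather than R. The only measured step, a step that the two limits leave unreadable from compound 1 to compound 2, is a change in the chain and not in configuration, and it gives no size to carry over. Among the compounds with values here, no measured pair isolates the inversion itself. With all three neighbours at the limit, the most likely outcome in this assay is another limit, and no clear gain in potency is expected. The expected change is a step that the limit leaves unreadable from compound 3 to compound 4, an estimate that carries little weight. For compound 4 the estimated value is 130000 nM, with an expected range from 50000 nM to 260000 nM.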

Compound 4, half-maximal inhibitory concentration: 22100 nM
For compound 4 the middle estimate is 5.9-fold (0.77 log units) above the measured one; the whole stated range lies above it.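

In this assay, compound 4 is the only compound shown that gives a number rather than a limit, so steps can now be read in this series: the limit of > 128000 nM in this assay, at which 3 of the 4 values shown sit. Inverting a stereocentre at a saturated ring carbon from R to S, with no other change, gives an at least 5.7-fold lower number from compound 3 to compound 4 (0.76 log units; beyond the scatter), so configuration at this position matters for this read-out: the fact that compounds 3 and 4 differ only in the configuration as drawn With the S configuration held, the chain also reads: ethyl in place of hydrogen on a saturated chain carbon, seven bonds along the chain from an amine nitrogen, gives an at least 5.7-fold lower number from compound 2 to compound 4 (0.76 log units; beyond the scatter), and methyl in place of hydrogen on a saturated chain carbon, eight bonds along the chain from an amine nitrogen, gives an at least 5.7-fold lower number from compound 1 to compound 4 (0.76 log units; beyond the scatter).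

Going by these compounds, compounds 1, 2 and 3 each stand at a limit, so the full size of all three steps stays open. Also open, on these data alone, is how a longer chain or a carboxylic acid on the shared core would read, and whether a longer chain would read the same way with the R configuration of compound 3.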